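Swapping hydroxy for fluoro in compound 1

The source may report more compounds than this note shows. Statements on the series, on what has been measured and on what is new or still open speak of the compounds shown alone.

Compound 1, `CC(=O)c1ccc(OCc2cccc(F)c2)cc1O`, was tested in an assay on isolated protein for inhibition of Amine oxidase [flavin-containing] A (Homo sapiens), read by fluorescence, with a stated time of 15 min; a higher number here means a weaker inhibitor, a lower number a stronger inhibitor. In this assay compound 1 returned only > 100000 nM, which is a limit of the assay and not a number. Among the three compounds measured it sits at the limit of > 100000 nM in this assay, at which 1 of the 3 values shown sits, so for compound 1 no real value is known. The two other compounds carry different cores. Compound 2, `O=c1ccoc2cc(OCc3ccc(C(F)(F)F)cc3)ccc12`, gives 18900 nM in this assay. Compound 3, `O=C1OCc2cc(OCc3ccc(F)cc3)ccc21`, gives 1330 nM in this assay. Among the compounds with values here, these two values belong to different structures, and no single step joins either of them to compound 1.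

Compound 4, `CC(=O)c1ccc(OCc2cccc(F)c2)cc1F`, keeps the core of compound 1 and differs in one place: fluoro in place of hydroxy on an aromatic carbon, ortho to the acetyl group. Within the data shown here, no measured pair shows the effect of this change, so any expectation rests on where compound 1 stands. Because compound 1 sits at the limit of > 100000 nM in this assay, at which 1 of the 3 values shown sits, the step from compound 1 to compound 4 is expected to be an at least 1.2-fold lower number from compound 1 to compound 4 (0.09 log units; that floor lies within the scatter), small and uncertain in direction, with a fair chance that this assay again reports only a limit. Compound 4 is estimated at 80000 nM in this assay, within a range from 15000 nM to 300000 nM.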

Compound 4, half-maximal inhibitory concentration: > 100000 nM
Compound 4 gave a limit, no number; the forecaster's own chance of this, stated with the estimate: 55%; at least 1.2-fold (0.09 log units) between middle value and limit.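

Within the data shown here, compound 4 returned > 100000 nM in this assay, which is a limit of the assay and not a number; compound 1 also gave only a limit, so no step between compound 1 and compound 4 can be read. The compounds shown leave open whether fluoro in place of hydroxy changes inhibition at all, because both compounds rest at the same limit: the limit of > 100000 nM in this assay, at which 2 of the 4 values shown sit.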